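The source may hold more compounds than are shown below. What is called first, only, known or untested is meant among the compounds shown, and "the series" means these compounds.

Compound 1 `CCn1ncnc1-c1ccccc1NCC1=NCCN1` and compound 2 `CC(C)n1ncnc1-c1ccccc1NCC1=NCCN1` share one core, while compound 3 `CC(C)n1nccc1-c1ccccc1NCC1=NCCN1` and compound 4 `CCn1nccc1-c1ccccc1NCC1=NCCN1` share another; the difference between the two cores is not broken down here. In a functional assay with Alpha-1A adrenergic receptor (Homo sapiens) as the target, read by calcium flux (on this read-out higher numbers stand for larger maximal responses and lower numbers for smaller maximal responses), compound 1 gives 107%, compound 2 gives 104%, and compound 3 gives 0%, the lowest of the three. The change hydrogen in place of methyl on a saturated chain carbon bound to an aromatic nitrogen and a saturated chain carbon produced the step of a number 3 percentage points higher from compound 2 to compound 1 (within the scatter). The same kind of change, (hydrogen in place of methyl on a saturated chain carbon bound to an aromatic nitrogen and a saturated chain carbon), leads from compound 3 to compound 4. Since the measured step of a number 3 percentage points higher from compound 2 to compound 1 (within the scatter) was small, the expected step is a number 3 percentage points higher from compound 3 to compound 4 (within the scatter). Compound 4 is therefore estimated at 3%, within a range from 0% to 15%, because compound 3 gives 0% and the change is not expected to move it far.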

Compound 4, largest response reached (reported as maximal response), in percent of the reference or control that the assay uses: 81%
Beside the measured number, compound 4's estimate is 78 percentage points below it, outside the stated range (above it).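

On the second core, the swap of isopropyl for ethyl gave a number 81 percentage points higher from compound 3 to compound 4 (beyond the scatter), whereas on the first core it gave a number 3 percentage points higher from compound 2 to compound 1 (within the scatter). In this assay, the change therefore did not carry over from one core to the other with the same size: the same change on two cores in this assay, a number 3 percentage points higher (within the scatter) from compound 2 to compound 1 and a number 81 percentage points higher (beyond the scatter) from compound 3 to compound 4, 78 percentage points apart, beyond the scatter of two such steps. This shows that a step read on one core of this series cannot simply be transferred to the other, but with a single pair on each core it does not show what in the cores sets the two steps apart, or how other changes would carry over.

The compounds shown leave open how a methyl group or a longer chain such as propyl would behave in the same place. As far as these compounds go, it also remains open whether the two cores would diverge in the same way with those groups.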